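Replacing a Pyrrolidine Ring with a Carboxylic Acid

A few compounds are considered here, and "the series" means these few. Any claim that something is new, unique, unknown or untested is made for them only; others in the source may bear on it.

This story concerns a small family sharing one core, tested in a functional assay on the whole organism (strain albino) for inhibition, with Rattus norvegicus as the target, read by paw edema, with stated times of 1 h and 2 h, at a dose of 20 mmol/kg by the intraperitoneal route; a higher number here means more inhibition at the dose given (going by the name of the read-out), a lower number less inhibition. Compound 1 `N#CC1=C(NCC(=O)N2CCOCC2)N(c2ccccc2)C(=O)N2CCCCC(N3CCCC3)C12` gives 69.8% in this assay. For the measured compounds named here, compound 2 `N#CC1=C(NCN2CCCC2)N(c2ccccc2)C(=O)N2CCCCC(N3CCCC3)C12` gives 26.6% in this assay, and among the two measured numbers it stands lowest, with compound 1 the only neighbour.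

Going by the values given here, the one measured step shows a number 43.2 percentage points lower from compound 1 to compound 2 (beyond the scatter), so trading the (morpholin-4-yl)carbonyl group for a pyrrolidin-1-yl ring cost a great deal of inhibition. Compound 3 `N#CC1=C(NCC(=O)O)N(c2ccccc2)C(=O)N2CCCCC(N3CCCC3)C12` has not yet been measured. It differs from compound 2 by carboxy in place of pyrrolidin-1-yl on a saturated chain carbon bound to an amine nitrogen, which means the pyrrolidin-1-yl ring leaves again and a carboxy group, with its one hydrogen-bond donor and one acceptor, takes its place on the same saturated chain carbon bound to the amine nitrogen.

Among the compounds with values here, the only step that bears on this is a number 43.2 percentage points lower from compound 1 to compound 2 (beyond the scatter); it suggests that the pyrrolidin-1-yl ring was unfavourable here, so its removal is expected to bring a step of a number 28.4 percentage points higher from compound 2 to compound 3 (beyond the scatter). Compound 3 is therefore estimated at 55%, within a range of 30% to 75%.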

Compound 3, a percentage reported as inhibition, in the whole organism at one dose (the size of the read-out at that dose, not a potency): 81.7%
The estimate for compound 3 lay 26.7 percentage points below the measured number; measured number above the stated range.
By their numbers in this assay, from the lowest: compound 2; then compound 1; then compound 3.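

In this assay the group on a saturated chain carbon bound to an amine nitrogen can move the read-out strongly upward as well as downward, since carboxy in place of pyrrolidin-1-yl brings a number 55.1 percentage points higher from compound 2 to compound 3 (beyond the scatter) and marks a large gain. The comparison with the amide adds what the first step could not show: hydroxy in place of morpholin-4-yl on a carbonyl carbon gives a number 11.9 percentage points higher from compound 1 to compound 3 (beyond the scatter) in a modest but real change, so the morpholin-4-yl ring is not needed for inhibition here, and compound 3 stands highest of the three. The two compounds with a carbonyl on that chain carbon, compound 1 and compound 3, both stand well above compound 2, which carries pyrrolidin-1-yl there, although three compounds can only hint at such a pattern.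

Still open, going by these compounds, is whether the carbonyl alone carries this gain or the acid hydrogen counts as well, a question that a methyl ester or a primary amide in that place would address, as would a longer chain ending in carboxy. Nothing in the data explains why these groups differ in effect.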